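From methylsulfonyl to acetamido on compound 2

The source may report more compounds than this note shows. Statements on the series, on what has been measured and on what is new or still open speak of the compounds shown alone.

In a functional assay on A549 cells (Homo sapiens) for cytotoxicity, read by MTT assay, with a stated time of 72 h (a lower number here means a stronger inhibitor, a higher number a weaker inhibitor), compound 2 `CS(=O)(=O)c1ccc(-c2ccnc(Nc3cccc(C(N)=O)c3)n2)cc1` gives > 100000 nM, which is a limit and not a number. Compound 3 `CS(=O)(=O)c1ccc(-c2ccnc(Nc3cccc(S(N)(=O)=O)c3)n2)cc1` gives > 100000 nM, likewise a limit. Both compounds stand at the limit of > 100000 nM in this assay, at which 2 of the 3 values shown sit. Only compound 1 `COc1ccc(-c2ccnc(Nc3ccc(C(N)=O)cc3)n2)cc1` gives a number, 5300 nM, and it differs from compound 2 in more than one place. Within the data shown here, the sole measured step is a step that the two limits leave unreadable from compound 2 to compound 3, which concerns a different group and offers no size to carry over. Compound 4 `CC(=O)Nc1ccc(-c2ccnc(Nc3cccc(C(N)=O)c3)n2)cc1` has acetamido in place of methylsulfonyl, para to a large group: acetamido in place of methylsulfonyl on an aromatic carbon. Among the measured compounds shown here, with compound 1 at 5300 nM as the only readable value, a modest gain in this assay is expected. A further limit remains possible for compound 4. The expected step is an at least 1.6-fold lower number from compound 2 to compound 4 (0.22 log units; that floor lies within the scatter). Compound 4 is estimated at 60000 nM, within an expected range of 15000 nM to 150000 nM.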

Compound 4, half-maximal inhibitory concentration: 33000 nM
Beside the measured number, compound 4's estimate is 1.8-fold (0.26 log units) above it; the range from low to high includes it.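

In this assay, among these compounds, acetamido in place of methylsulfonyl, para to a large group, gives an at least 3.0-fold lower number from compound 2 to compound 4 (0.48 log units; beyond the scatter), the first readable step and the first sign that this position can move the value with the carbamoyl side held fixed. The true size of the step stays unknown because compound 2 gives only a limit: the limit of > 100000 nM in this assay, at which 2 of the 4 values shown sit.

Open: whether a free amine or a carboxylic acid at this position would act as acetamido does. From the compounds shown here alone, also open: whether a longer acyl chain would shift the value further.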